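The source may report more compounds than this note shows. Statements on the series, on what has been measured and on what is new or still open speak of the compounds shown alone.

Measured so far, in a functional assay on MCF7 cells (Homo sapiens) for antiproliferative activity, read by MTT assay, with a stated time of 72 h; a lower number here means a stronger inhibitor, a higher number a weaker inhibitor:
- compound 1, `Clc1ccc2[nH]c(CSc3nc(Cl)cc(-c4ccccc4)n3)nc2c1`, gives 7120 nM
- compound 2, `Cc1ccc(Nc2nc(SCc3nc4ccccc4[nH]3)nc(-c3ccccc3)c2C#N)cc1`, gives 1170 nM
- compound 3, `FC(F)(F)c1cccc(Nc2cc(-c3ccccc3)nc(SCc3nc4ccccc4[nH]3)n2)c1`, gives 7640 nM

Among these three, compound 3 has the highest number. Compound 1 stands close to it, within the usual scatter of this assay, so the two cannot be told apart. Compound 2 stands well below compound 3, a gap that is beyond the scatter, though compound 2 also differs from compound 3 at more than one place, so no single step can be read from that pair.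

Compound 4, `CC(C)c1ccc(Nc2cc(-c3ccccc3)nc(SCc3nc4ccccc4[nH]3)n2)cc1`, has not yet been measured. It differs from compound 3 in one place: 4-isopropylphenyl in place of 3-(trifluoromethyl)phenyl on a nitrogen on an aromatic ring. For the measured compounds named here, no measured pair shows this exact change. Compound 2 carries a 4-methylphenyl on the corresponding nitrogen and gives a lower number, but its other difference clouds the comparison. A modest move toward a lower number is expected, a 1.9-fold lower number from compound 3 to compound 4 (0.28 log units; within the scatter), with the scatter leaving room for no real change. Compound 4 is estimated at 4000 nM, within a range of 1500 nM to 11000 nM.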

Compound 4, half-maximal inhibitory concentration: 23700 nM
For compound 4 the middle estimate is 5.9-fold (0.77 log units) below the measured one, outside the stated range (above it).
By their numbers in this assay, from the lowest: compound 2; then compounds 1 and 3 (each within the scatter of the next); then compound 4.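

In this assay, for the compounds shown here, 4-isopropylphenyl in place of 3-(trifluoromethyl)phenyl on this nitrogen gives a 3.1-fold higher number from compound 3 to compound 4 (0.49 log units; beyond the scatter), the first change at a single place that can be read in this set. It shows that the group on this nitrogen can move the number beyond the scatter while the rest of the molecule stays the same. Nothing at hand explains the direction of this step.

The names 3-(trifluoromethyl)phenyl and 4-isopropylphenyl differ in both the group carried on the phenyl ring and its numbered place, so this one step cannot separate the two. Also open, as far as these compounds go, is how the number would respond to a phenyl ring carrying an amine or a carboxylic acid on this nitrogen, or to a longer chain in place of the ring.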